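A few compounds are considered here, and "the series" means these few. Any claim that something is new, unique, unknown or untested is made for them only; others in the source may bear on it.

Compound 1 `O=c1cc(/C=N\O)c2c(OCc3ccccc3)cc(OCc3ccccc3)cc2o1` carries an oxime on a shared core that bears two benzyloxy groups. In a functional assay, read by spectrophotometry, with a stated time of 3 min (a lower number here means a stronger inhibitor, a higher number a weaker inhibitor), compound 1 gives 38700 nM, the highest of the two numbers measured here, meaning the weakest inhibition of the pair. Going by the values given here, its only neighbour is compound 2 `Nc1ccccc1/N=C\c1cc(=O)oc2cc(OCc3ccccc3)cc(OCc3ccccc3)c12`, which in this assay gives 7530 nM; that pair shows a 5.1-fold lower number from compound 1 to compound 2 (0.71 log units; beyond the scatter), a change on the double-bonded nitrogen rather than on the core itself.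

Compound 3 `O=c1cc(/C=N\O)c2ccc(OCc3ccccc3)cc2o1` keeps the oxime and instead alters the core: hydrogen in place of benzyloxy on an aromatic carbon The group that leaves sits on an aromatic carbon of a six-membered aromatic ring of carbon only, part of a fused system of two rings, meta to the remaining benzyloxy group. Among the compounds with values here, no measured step touches that position, so the single step available says little about it beyond showing that the core tolerates change elsewhere with a modest result. With nothing to anchor the direction, the expected step is a 1.3-fold higher number from compound 1 to compound 3 (0.11 log units; within the scatter), carrying wide uncertainty. Compound 3 is therefore expected to give 50000 nM, within a range from 12000 nM to 200000 nM.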

Compound 3, half-maximal inhibitory concentration: 22800 nM
For compound 3 the middle estimate is 2.2-fold (0.34 log units) above the measured one; the range from low to high includes it.
By their numbers in this assay, from the lowest: compound 2; then compounds 3 and 1 (each within the scatter of the next).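

In this assay, replacing the benzyloxy group with hydrogen on this aromatic carbon gives a 1.7-fold lower number from compound 1 to compound 3 (0.23 log units; within the scatter). Going by these compounds alone, this is the first look at this position, and it shows that a group of 8 heavy atoms, including a whole six-membered aromatic ring, can leave the shared core while compound 3 and compound 1 remain indistinguishable in this assay, so with the oxime in place, the benzyloxy group at this position makes no difference that can be read here. No supporting data bear on the reason for this result.

The compounds shown hold only benzyloxy and hydrogen at this position, so it remains open whether a methoxy group, a hydroxy group or an amine here would read any differently. From the compounds shown here alone, it is also open whether the same swap would read the same way with the 2-aminophenyl group of compound 2 on the double-bonded nitrogen, as this single step rests on the oxime alone and a result from one pair need not carry over to another.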